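Adding a Further Methoxy Group to Compound 3

The compounds below may be only part of what the source reports. "The series", "measured", "known", "first", "only" and "open" are said of these compounds alone.

Compound 1 `O=C1C=COC(/C=C/c2ccccc2)C1` and compound 2 `COc1ccc(/C=C/C2CC(=O)C=CO2)cc1` share one core, while compound 3 `COc1cc(/C=C/C2CC=CC(=O)N2)cc(OC)c1` is built on another; the difference between the two cores is not broken down here. In a functional assay on MCF7 cells (Homo sapiens) for inhibition, read by sulforhodamine B assay, with a stated time of 48 h (a higher number here means a weaker inhibitor of growth, a lower number a stronger inhibitor of growth), compound 1 gives 153 uM. In this assay compound 2 gives 156 uM, and in this assay compound 3 gives 146 uM. The three numbers lie within the scatter of one another, so none of these compounds can be set apart from the others on this evidence.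

The change from compound 1 to compound 2 is methoxy in place of hydrogen on an aromatic carbon and it brought a 1.0-fold higher number from compound 1 to compound 2 (0.01 log units; within the scatter).

Compound 4 `COc1cc(/C=C/C2CC=CC(=O)N2)cc(OC)c1OC` has not yet been measured. It differs from compound 3 by methoxy in place of hydrogen on an aromatic carbon. This is the same kind of change as that between compound 1 and compound 2, though the surroundings are not identical: in compound 4 the entering group sits ortho to two methoxy groups (2 heavy atoms each) and para to a group of 9 heavy atoms, whereas in compound 2 it sits only para to a group of 9 heavy atoms.

Because the earlier step of this kind gave a 1.0-fold higher number from compound 1 to compound 2 (0.01 log units; within the scatter), the step in this assay is expected to be a 1.0-fold higher number from compound 3 to compound 4 (0.01 log units; within the scatter). Compound 4 is therefore estimated at 150 uM, with a likely range from 60 uM to 400 uM.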

Compound 4, concentration for growth inhibition (reported as GI): > 864 uM
Compound 4 was reported as a limit (the forecaster's own chance of this, stated with the estimate: 20%); middle value at least 5.7-fold (0.76 log units) from the limit.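

In this assay compound 4 gives > 864 uM, which is a limit of the assay and not a number. Methoxy in place of hydrogen on an aromatic carbon brought an at least 5.9-fold higher number from compound 3 to compound 4 (0.77 log units; beyond the scatter), so in this series the change did not carry over from one core to the other with the same result, and the two steps differ: the same change on two cores in this assay, a 1.0-fold higher number (0.01 log units; within the scatter) from compound 1 to compound 2 and an at least 5.9-fold higher number (0.77 log units; beyond the scatter) from compound 3 to compound 4, at least 5.8-fold (0.76 log units) apart, beyond the scatter of two such steps This does not show what separates the two steps, nor the full size of the second one, which the limit leaves unfixed; the cores differ, and so do the surroundings of the entering group, which in compound 4 sits ortho to two methoxy groups and para to a group of 9 heavy atoms, so this single pair of steps cannot tell the part played by the core from that of the neighbouring groups.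

The compounds shown leave open what the same methoxy would do on the core of compound 1 when it enters ortho to two methoxy groups, which would pull those two factors apart. They also leave open whether a hydroxy group or a chlorine atom in that same place on the core of compound 3 would bring a step of this kind.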